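The compounds below may be only part of what the source reports. "The series", "measured", "known", "first", "only" and "open" are said of these compounds alone.

Measured so far:
compound 1 `CC(=O)n1cc(/C=C(/C(=O)O)c2ccc(Cl)cc2)c2cc(OCc3ccccc3)ccc21` — > 100000 nM
compound 2 `COc1ccc(/C(=C\c2cn(C(C)=O)c3ccc(OCc4ccccc4)cc23)C(=O)O)cc1OC` — > 100000 nM
compound 3 `COc1ccc(/C(=C\c2c[nH]c3ccc(OCc4ccccc4)cc23)C(=O)O)cc1` — "not determined" (no result reported)

In a functional assay on LNCaP cells (Homo sapiens) for cytotoxicity, read by MTT assay, with a stated time of 72 h (a higher number here means a weaker inhibitor, a lower number a stronger inhibitor), compound 1 gives > 100000 nM, which is a limit of the assay and not a number. Compound 2 gives > 100000 nM, also a limit. Compound 3 was not measured. Among the compounds with values here, the one measured step, a step that the two limits leave unreadable from compound 1 to compound 2, cannot be read in size because of the limit of > 100000 nM in this assay, at which 2 of the 3 values shown sit.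

Compound 4 `COc1ccc(OC)c(/C(=C\c2cn(C(C)=O)c3ccc(OCc4ccccc4)cc23)C(=O)O)c1` differs from compound 1 by 2,5-dimethoxyphenyl in place of 4-chlorophenyl on a double-bonded chain carbon bound to a carbonyl carbon and a double-bonded chain carbon. Within the data shown here, the only step that bears on this change is a step that the two limits leave unreadable from compound 1 to compound 2, and it gives no readable size, so no step beyond the scatter can be expected in either direction. Compound 4 is therefore estimated near 150000 nM, within 50000 nM to 500000 nM, an expected step that the limit leaves unreadable from compound 1 to compound 4.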

Compound 4, half-maximal inhibitory concentration: 44100 nM
Beside the measured number, compound 4's estimate is 3.4-fold (0.53 log units) above it; the measured number lies below the stated range.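

In this assay, the group on the double-bonded chain carbon bound to a carbonyl carbon and a double-bonded chain carbon now has a readable effect: 2,5-dimethoxyphenyl gives an at least 2.2-fold lower number from compound 1 to compound 4 (0.35 log units; beyond the scatter). In place of 3,4-dimethoxyphenyl, it gives an at least 2.2-fold lower number from compound 2 to compound 4 (0.35 log units; beyond the scatter), so having two methoxy groups does not alone decide the result; their places on the ring also count. Compound 1 and compound 2 gave no readable step: the limit of > 100000 nM in this assay, at which 2 of the 4 values shown sit.

On these data alone, both new steps rest on a limit, so their full size remains open. Also open, as far as these compounds go, is whether a single methoxy group, or an amine on that ring, would give a similar result.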